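The source may report more compounds than this note shows. Statements on the series, on what has been measured and on what is new or still open speak of the compounds shown alone.

Compound 2 `CCCS(=O)(=O)Nc1ccc(F)c(C(=O)c2n[nH]c3ncc(-c4ccc(S(=O)(=O)NC)cc4)cc23)c1F` gives 1.2% in an assay for binding affinity to dual specificity mitogen-activated protein kinase kinase 4 (Homo sapiens), read by KINOMEscan, tested at 100 nM (a lower number here means a stronger effect, a higher number a weaker effect of the compound at the concentration tested), the lowest of the two numbers in hand. Compound 1 `CCCS(=O)(=O)Nc1ccc(F)c(C(=O)c2n[nH]c3ncc(-c4cccc(C)c4)cc23)c1F` gives 15% under the same conditions, and the step of a number 13.8 percentage points lower from compound 1 to compound 2 (beyond the scatter) shows how much the change on that aromatic carbon mattered. Compound 3 `CCCS(=O)(=O)Nc1ccc(F)c(C(=O)c2n[nH]c3ncc(-c4ccc(S(N)(=O)=O)cc4Cl)cc23)c1F` differs from compound 2 by 2-chloro-4-sulfamoylphenyl in place of 4-(methylsulfamoyl)phenyl on an aromatic carbon. Going by the values given here, no measured step covers this exact change; only the step from compound 1 to compound 2 bears on it, and that one already reached a number near the floor of the read-out. The expected step of a number 0.8 percentage points higher from compound 2 to compound 3 (within the scatter) is therefore small, not beyond the scatter. Compound 3 is estimated at 2%, within 0.3% to 12%.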

Compound 3, a percentage reported as activity, at one concentration (the size of the read-out at that concentration, not a potency): 3.4%
Compound 3: middle estimate off by 1.4 percentage points, on the low side; the range from low to high includes it.
By their numbers in this assay, from the lowest: compounds 2 and 3 (each within the scatter of the next); then compound 1.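

Putting 2-chloro-4-sulfamoylphenyl in place of 4-(methylsulfamoyl)phenyl gives a number 2.2 percentage points higher from compound 2 to compound 3 (within the scatter) in this assay, so this position accepts both groups without a readable difference. Against 3-methylphenyl, the new group gives a number 11.6 percentage points lower from compound 1 to compound 3 (beyond the scatter), so a second sulfamoyl-bearing phenyl group also sits clearly lower than compound 1. No available evidence explains these numbers. The chlorine and the loss of the nitrogen's methyl change together, leaving their separate contributions unresolved. On these data alone, whether a carboxylic acid or an amine in place of the sulfamoyl group would keep the number this low also remains open.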